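Shifting the methoxy group: from compound 2 to compound 3

This account rests on a few compounds, and the source may have more. Where it says the series, first, only, none or still open, it means among the compounds named here.

Compound 1 `COc1ccc(COC(=O)[C@@H](CC(=O)OC2CCCC2)NC(=O)OC(C)(C)C)cc1` gives 2000 nM in a functional assay on IMR-32 cells for inhibition of Voltage-dependent N-type calcium channel subunit alpha-1B (Homo sapiens), read by calcium flux; on this read-out lower numbers stand for stronger inhibition and higher numbers for weaker inhibition.
Compound 2 `COc1ccc(COC(=O)[C@H](CC(=O)OC2CCCC2)NC(=O)OC(C)(C)C)cc1` gives 3400 nM in this assay.

Among the measured compounds shown here, compound 2 stands at the higher of the two numbers recorded so far, but the gap to compound 1 is small: the step of a 1.7-fold higher number from compound 1 to compound 2 (0.23 log units; within the scatter) lies within the scatter, and the only thing separating the pair is the fact that compounds 1 and 2 differ only in the configuration as drawn. The two compounds therefore count as equal on this read-out.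

The unmeasured compound 3 `COc1cccc(COC(=O)[C@H](CC(=O)OC2CCCC2)NC(=O)OC(C)(C)C)c1` keeps every atom of compound 2 and changes only where the oxygen sits on the aromatic ring: 3-methoxyphenyl in place of 4-methoxyphenyl on a saturated chain carbon bound to an oxygen next to a carbonyl group. For the measured compounds named here, no measured step touches this part of the molecule. Going by the values given here, the one step available, from compound 1 to compound 2, concerns a different position and is itself within the scatter, so it offers no guide to the size or direction of the present change. On that footing no step beyond the scatter is expected in this assay, and the estimate for the step is no change at the digits printed from compound 2 to compound 3 (within the scatter). Compound 3 is accordingly expected to give about 3400 nM, within a range from 1000 nM to 12000 nM.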

Compound 3, half-maximal inhibitory concentration: 3800 nM
For compound 3 the middle estimate is 1.1-fold (0.05 log units) below the measured one; low and high end bracket the measured number.
By their numbers in this assay, from the lowest: compounds 1, 2 and 3 (each within the scatter of the next).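

The exchange of 4-methoxyphenyl for 3-methoxyphenyl on a saturated chain carbon bound to an oxygen next to a carbonyl group gives a 1.1-fold higher number from compound 2 to compound 3 (0.05 log units; within the scatter) in this assay, so the two compounds count as equal on this read-out. Among the compounds shown here, compounds 1 and 2 had spoken only to the configuration drawn at a stereocentre, whereas this pair is the first to test where the methoxy group sits on the aromatic ring, and this assay does not separate the 4-methoxyphenyl and 3-methoxyphenyl groups in this pair. Nothing available here bears on why the two groups read alike.

The compounds shown leave open whether the read-out would respond to a different group in this place, such as a plain phenyl ring or a ring carrying a hydroxyl group, an amine or a carboxylic acid instead of the methoxy group. They also leave open whether 3-methoxyphenyl would read the same when paired with the configuration drawn in compound 1, and whether a longer chain between the ring and the ester oxygen would be tolerated in the same way.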